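This account rests on a few compounds, and the source may have more. Where it says the series, first, only, none or still open, it means among the compounds named here.

Compound 1 `O=C(Nc1ccc(Oc2ccnc3[nH]ccc23)c(F)c1)c1nn(-c2ccccc2)ccc1=O`: 24900 nM
Compound 2 `Cc1cc(=O)n(-c2ccc(F)cc2)nc1C(=O)Nc1ccc(Oc2ncnc3[nH]ccc23)cc1`: > 60000 nM

In a functional assay on HepG2 cells (Homo sapiens) for cytotoxicity, read by MTT assay, with a stated time of 72 h (on this read-out higher numbers stand for weaker inhibition and lower numbers for stronger inhibition), compound 1 gives 24900 nM. For compound 2 the reading of > 60000 nM is a limit of the assay and not a number. Compound 2 therefore stands at the limit of > 60000 nM in this assay, at which 1 of the 2 values shown sits. Compound 3 `Cc1cc(=O)n(-c2ccc(Br)cc2F)nc1C(=O)Nc1ccc(Oc2ncnc3[nH]ccc23)cc1` differs from compound 2 by 4-bromo-2-fluorophenyl in place of 4-fluorophenyl on an aromatic nitrogen. Within the data shown here, no measured pair shows what such a change does, so no step beyond the usual scatter is assumed in either direction. Compound 3 is expected to give 60000 nM, somewhere between 20000 nM and 150000 nM, which amounts to an estimated step of a number no higher from compound 2 to compound 3 (the limit leaves the size open).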

Compound 3, half-maximal inhibitory concentration: 3660 nM
Estimate against measurement, compound 3: 16-fold (1.21 log units) above; measured number outside the range, below it.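

In this assay, among these compounds, placing 4-bromo-2-fluorophenyl instead of 4-fluorophenyl on the aromatic nitrogen gives an at least 16-fold lower number from compound 2 to compound 3 (1.21 log units; beyond the scatter), the first sign that the group at this position can strongly shift the read-out. Compound 2 stands at a limit of the assay and not at a number, so the full size of this step stays open: the limit of > 60000 nM in this assay, at which 1 of the 3 values shown sits.

The compounds shown do not separate the contribution of the bromine from that of the fluorine's new place on the ring. On these data alone, whether a plain 4-bromophenyl, a 2-fluorophenyl or a 4-chlorophenyl would give a similar step also remains open.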